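Swapping the Halogenated Aryl Ether of Compound 1

A few compounds are considered here, and "the series" means these few. Any claim that something is new, unique, unknown or untested is made for them only; others in the source may bear on it.

Compound 1 `Nc1cc(N)c2nc(-c3ccccc3)c(Oc3ccc(Cl)c(Cl)c3)nc2c1` is characterised in a functional assay on U-251 cells (Homo sapiens) for inhibition, read by sulforhodamine B assay, with a stated time of 48 h (a higher number here means that more compound is tolerated, a lower number that less compound is tolerated), where compound 1 gives 83200 nM. Compound 2 `COc1ccc(CNc2nc3cc(N)cc(N)c3nc2-c2ccccc2)cc1OC`, which carries a different substituent on the shared core, gives 89100 nM in this assay; the two numbers sit within the usual scatter of each other, so neither compound stands apart on this read-out. Compound 3 `Nc1cc(N)c2nc(-c3ccccc3)c(Oc3ccc(F)cc3)nc2c1` has not been measured yet. Its difference from compound 1 is 4-fluorophenyl in place of 3,4-dichlorophenyl on an oxygen on an aromatic ring. Within the data shown here, no measured pair shows this change, so nothing here tells how much it moves the read-out of this assay. The expected size of the step is a 1.2-fold higher number from compound 1 to compound 3 (0.08 log units; within the scatter), which amounts to no change beyond the scatter. Compound 3 is therefore estimated at 100000 nM in this assay, with a range from 40000 nM to 250000 nM.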

Compound 3, concentration lethal to 50% of the cells: < 100000 nM
Compound 3 gave a limit, no number; the forecaster's own chance of this, stated with the estimate: 25%; the middle value sits exactly at the limit.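

In this assay compound 3 gives < 100000 nM, which is a limit of the assay and not a number, so no step can be read between compound 1 and compound 3. From the compounds shown here alone, whether 4-fluorophenyl in place of 3,4-dichlorophenyl moves the read-out at all stays open.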